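The source may report more compounds than this note shows. Statements on the series, on what has been measured and on what is new or still open speak of the compounds shown alone.

Three oxime ethers have been measured in an assay on brain (strain Sprague-Dawley) for displacement of a labelled ligand from metabotropic glutamate receptor 5 (Rattus norvegicus), with a stated time of 45 min; on this read-out higher numbers stand for weaker inhibition and lower numbers for stronger inhibition. Compound 1 `CO/N=C1/C=C(C#Cc2ccncc2)CCC1` gives 54.8 nM, compound 2 `Fc1cccc(O/N=C2\C=C(C#Cc3ccccn3)CCC2)n1` gives 44 nM, and compound 3 `N#Cc1ccc(O/N=C2\C=C(C#Cc3ccccn3)CCC2)cc1F` gives 49.8 nM. Compound 3 holds the second highest of the three numbers, but its nearest neighbour, compound 1, sits only within the scatter of it, and so does compound 2, so the three values cannot be told apart on this read-out.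

Compound 4 `N#Cc1ccc(O/N=C2/C=C(C#Cc3ccccn3)CCC2)cc1F` has not yet been measured. The two compounds have the same atoms and bonds and differ only in configuration as drawn: the two compounds have the same atoms and bonds and differ only in configuration as drawn: 1 of 1 stereo elements differ; a double bond is drawn Z in compound 3 and E in compound 4. No measured pair shows what such a change of drawn geometry does here, so the direction rests on no shown step.

With the change confined to the oxime double bond and nothing else entering or leaving, compound 4 is expected to move toward a weaker inhibition by a moderate step, a 2.4-fold higher number from compound 3 to compound 4 (0.38 log units; beyond the scatter), with wide uncertainty. The estimated value for compound 4 in this assay is 120 nM, with a range from 20 nM to 1500 nM.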

Compound 4, inhibition constant: 56.1 nM
Compound 4: the middle estimate sits 2.1-fold (0.33 log units) above what was measured; measured number inside the range.
By their numbers in this assay, from the lowest: compounds 2, 3, 1 and 4 (each within the scatter of the next).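

Among the compounds shown here, compounds 3 and 4 give the first pair in the set that differ in one place, and the comparison isolates the geometry of the oxime double bond: the fact that compounds 3 and 4 differ only in the configuration as drawn. In this assay, going from Z to E as drawn gives a 1.1-fold higher number from compound 3 to compound 4 (0.05 log units; within the scatter), so this pair shows no measurable dependence on the drawn geometry at this position. Both geometries therefore fit the same range of binding values as the other oxime ethers, at least with the group carrying the nitrile and fluorine.

Whether the same indifference holds for the methyl ether of compound 1 or the fluorinated ether of compound 2 stays open, as their geometric partners are absent from the compounds shown. Also open, from the compounds shown here alone, is how either geometry would behave with an amine or a carboxylic acid on the oxime ether group.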